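Swapping the tetrazole of compound 3 at the assay limit

A few compounds are considered here, and "the series" means these few. Any claim that something is new, unique, unknown or untested is made for them only; others in the source may bear on it.

In a functional assay on MOLM-13 cells (Homo sapiens) for antiproliferative activity (on this read-out higher numbers stand for weaker inhibition and lower numbers for stronger inhibition), compound 3 `Cc1c(-c2ccc(-c3ccccc3F)cc2)nc2ccc(F)cc2c1-c1nnn[nH]1` gives > 3000 nM, which is a limit and not a number. Compound 1 `Cc1c(-c2ccc(-c3ccccc3F)cc2)nc2ccc(F)cc2c1CO` gives 700 nM and compound 2 `Cc1c(-c2ccc(-c3ccccc3F)cc2)nc2ccc(F)cc2c1C(O)C(F)(F)F` gives 640 nM, and the two lie within the scatter: a 1.1-fold lower number from compound 1 to compound 2 (0.04 log units; within the scatter). Compound 4 `Cc1c(-c2ccc(-c3ccccc3F)cc2)nc2ccc(F)cc2c1-c1noc(=O)[nH]1` carries a different ring on the same aromatic carbon: a group of 6 heavy atoms (2 carbon, 2 nitrogen, 2 oxygen; one five-membered aromatic ring with 3 hetero atoms) in place of a group of 5 heavy atoms (1 carbon, 4 nitrogen; one five-membered aromatic ring with 4 hetero atoms), on an aromatic carbon. The nearest measured steps, an at least 4.2-fold higher number from compound 1 to compound 3 (0.63 log units; beyond the scatter) and an at least 4.6-fold higher number from compound 2 to compound 3 (0.67 log units; beyond the scatter), both bring in 1H-tetrazol-5-yl and both lie beyond the scatter, yet neither exchanges one ring for another. No step beyond the scatter is therefore expected for this exchange, and the estimate is an at least 1.2-fold lower number from compound 3 to compound 4 (0.07 log units; that floor lies within the scatter). In this assay the estimated value for compound 4 is 2500 nM, with an expected range of 800 nM to 6000 nM.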

Compound 4, half-maximal inhibitory concentration: > 3000 nM
Compound 4: only a limit was reported (the forecaster's own chance of this, stated with the estimate: 45%); middle value at least 1.2-fold (0.07 log units) away from the limit.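

In this assay compound 4 gives > 3000 nM as a limit and not a number. The loss on this aromatic carbon is not confined to 1H-tetrazol-5-yl: the oxygen-containing ring of compound 4 also lies beyond the scatter from both hydroxyl-bearing groups (an at least 4.2-fold higher number from compound 1 to compound 4 (0.63 log units; beyond the scatter); an at least 4.6-fold higher number from compound 2 to compound 4 (0.67 log units; beyond the scatter)). The steps between compound 3 and compound 4 cannot be read, so the two rings cannot be ranked, with both compounds at the same limit: the limit of > 3000 nM in this assay, at which 2 of the 4 values shown sit.

Still open, going by these compounds, is how far compound 3 and compound 4 lie beyond that limit. Also open, on these data alone, is whether a carboxylic acid or an amine on this aromatic carbon would sit with compound 1 and compound 2 or at the limit.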